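A few compounds are considered here, and "the series" means these few. Any claim that something is new, unique, unknown or untested is made for them only; others in the source may bear on it.

Notes on the series. In a functional assay on cells (Leukemia cell, Homo sapiens) for cytotoxicity, read by sulforhodamine B assay, with a stated time of 48 h (a higher number here means a weaker inhibitor of growth, a lower number a stronger inhibitor of growth), compound 1 `COc1ccc(C2=NN(C3=NC(=O)/C(=C4\C(=O)Nc5ccc(Br)cc54)S3)C(c3ccc(OC)cc3)C2)cc1` gives 62700 nM. Compound 2 `COc1ccc(C2=NN(C3=NC(=O)/C(=C4\C(=O)Nc5ccccc54)S3)C(c3ccc(Cl)cc3)C2)cc1` gives in this assay 90900 nM, the higher of the two numbers recorded so far; the gap to compound 1 lies within the usual scatter, so the two compounds cannot be ordered on these data. Going by the values given here, compound 1 and compound 2 differ in two places, and no single step connects them. Compound 3 `COc1ccc(C2=NN(C3=NC(=O)/C(=C4\C(=O)Nc5ccc(Br)cc54)S3)C(c3ccc(Cl)cc3)C2)cc1` arises from compound 2 by bromo in place of hydrogen on an aromatic carbon. Among the compounds with values here, no measured step of this kind exists, so the expectation for this assay is a small step, at most modestly toward a lower number, and quite possibly not beyond the scatter. The estimate for compound 3 in this assay is 65000 nM, with a range from 30000 nM to 130000 nM. The expected step from compound 2 to compound 3 is a 1.4-fold lower number from compound 2 to compound 3 (0.15 log units; within the scatter).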

Compound 3, concentration for total growth inhibition: 14000 nM
Beside the measured number, compound 3's estimate is 4.6-fold (0.67 log units) above it, and the stated range ends above it.
By their numbers in this assay, from the lowest: compound 3; then compounds 1 and 2 (each within the scatter of the next).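

In this assay, bromo in place of hydrogen on an aromatic carbon of the ring fused to the rest of the core gives a 6.5-fold lower number from compound 2 to compound 3 (0.81 log units; beyond the scatter), the first sign in the series that this position responds to substitution by more than the scatter. With bromo held fixed, chloro in place of methoxy on an aromatic carbon gives a 4.5-fold lower number from compound 1 to compound 3 (0.65 log units; beyond the scatter), so the result at this position is read alongside a second position that also shifts the number. No measurement at hand explains either step.

The compounds shown leave open whether the bromo step carries over when methoxy stands in place of chloro. Also open, as far as these compounds go, is whether fluoro, an amine or a carboxylic acid on the same aromatic carbon would behave as bromo does.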